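A few compounds are considered here, and "the series" means these few. Any claim that something is new, unique, unknown or untested is made for them only; others in the source may bear on it.

Measured so far in an ADME assay on microsomes from liver (Homo sapiens) for metabolic stability, with a stated time of 10 min; a lower number here means that less of the compound is left, a higher number that more of the compound is left
compound 1 `C[C@]1(C(=O)N2CC[C@](c3ccc(C(F)(C(F)(F)F)C(F)(F)F)cc3)(S(=O)(=O)c3ccc(F)cc3)C2)CC[C@H](C(=O)O)CC1` gives 80%
compound 2 `O=C(O)C12CCC(C(=O)N3CC[C@](c4ccc(C(F)(C(F)(F)F)C(F)(F)F)cc4)(S(=O)(=O)c4ccc(F)cc4)C3)(CC1)OC2` gives 90%

In this assay, among the compounds with values here, compound 2 stands at 90% and so lies within the scatter of compound 1 at 80%, the only other number available. Compound 3 `O=C(C1CCS(=O)(=O)CC1)N1CC[C@](c2ccc(C(F)(C(F)(F)F)C(F)(F)F)cc2)(S(=O)(=O)c2ccc(F)cc2)C1` has yet to be measured. It differs from compound 2 by a group of 8 heavy atoms (5 carbon, 2 oxygen, 1 sulfur; one six-membered non-aromatic ring with 1 hetero atom) in place of a group of 11 heavy atoms (8 carbon, 3 oxygen; one six-membered non-aromatic ring of carbon only, one six-membered non-aromatic ring with 1 hetero atom), on a carbonyl carbon. The 1,1-dioxothian-4-yl group sits on a carbonyl carbon whose other neighbours are amide-type nitrogen in a ring, the same place at which compound 1 and compound 2 differ.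

Within the data shown here, one measured step bears on this change: a number 10 percentage points higher from compound 1 to compound 2 (within the scatter). Among the measured compounds shown here, it is a single step, and no measured compound carries the 1,1-dioxothian-4-yl group, so it offers only a thin guide. Taking compound 2 at 90% as the starting point, no step beyond the scatter is expected in this assay. The estimated move is a number 5 percentage points lower from compound 2 to compound 3 (within the scatter). For compound 3 the estimate is 85%, with an expected range from 65% to 98%.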

Compound 3, percent of the compound remaining: 93%
Compound 3: middle estimate off by 8 percentage points, on the low side; low and high end bracket the measured number.
By their numbers in this assay, from the lowest: compounds 1, 2 and 3 (each within the scatter of the next, the first and the last beyond it).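

In this assay, the position on a carbonyl carbon whose other neighbours are amide-type nitrogen in a ring now holds a group without a carboxylic acid, the 1,1-dioxothian-4-yl group with 0 hydrogen-bond donors, and the change from the bicyclic acid group is small (a number 3 percentage points higher from compound 2 to compound 3 (within the scatter)). Set against the 4-carboxy-1-methylcyclohexyl group, the same 1,1-dioxothian-4-yl group gives the first step at this position to pass the scatter (a number 13 percentage points higher from compound 1 to compound 3 (beyond the scatter)), so a carboxylic acid in this group is not needed for much of the compound to remain in this assay, at least among compound 1, compound 2 and compound 3. No measurement is available here that would account for these steps.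

What the compounds shown leave open is whether the result belongs to the sulfur-containing ring itself, since an open-chain sulfone, a plain cyclohexyl group or a tetrahydropyran ring at this position would separate the ring from its two oxygens. On these data alone, it also remains open how an amine or a primary amide on this group would read out in this assay, and whether the picture holds for any read-out other than this one.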